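A few compounds are considered here, and "the series" means these few. Any claim that something is new, unique, unknown or untested is made for them only; others in the source may bear on it.

Compound 1, `Cc1ccccc1NC(=O)Nc1cc(C(C)(C)C)nn1-c1ccccc1`, in an assay on isolated protein for inhibition of STE20-like serine/threonine-protein kinase (Homo sapiens), read by thermal shift assay, tested at 10 uM; on this read-out higher numbers stand for stronger stabilisation of the target against heat and lower numbers for weaker stabilisation of the target: 7.1 degrees C
Compound 2, `Cn1nc(C(C)(C)C)cc1NC(=O)Nc1cc(C(F)(F)F)cc(C(F)(F)F)c1`, in this assay: 2.4 degrees C

Compound 1 stands at the top of these two numbers. Among the compounds with values here, compound 2, which differs from it in more than one place, gives a value that sits a good way lower, well beyond the usual scatter of this assay, and since the two differ at several points no single structural step can be tied to that gap.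

Compound 3, `CC(C)(C)c1cc(NC(=O)Nc2cc(F)cc(F)c2)n(-c2ccccc2)n1`, has not yet been measured. It comes from compound 1 by one change: 3,5-difluorophenyl in place of 2-methylphenyl on an amide-type nitrogen. Within the data shown here, no measured pair shows this particular exchange, so the expectation rests on the two values above alone. Among the measured compounds shown here, a modest fall from compound 1 to compound 3 is expected, a number 1.6 degrees C lower from compound 1 to compound 3 (beyond the scatter), because the only other change seen at this position in compound 2 gave 2.4 degrees C. Compound 3 is therefore estimated at 5.5 degrees C, with a range from 3 degrees C to 8 degrees C.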

Compound 3, shift of the target's melting temperature: 3 degrees C
For compound 3 the middle estimate is 2.5 degrees C above the measured one, within the range that was stated.
By their numbers in this assay, from the lowest: compounds 2 and 3 (each within the scatter of the next); then compound 1.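

Exchanging 2-methylphenyl for 3,5-difluorophenyl on the amide-type nitrogen, with the rest of compound 1 left untouched, gives the first reading tied to a single change: in this assay the exchange gives a number 4.1 degrees C lower from compound 1 to compound 3 (beyond the scatter). The group on this nitrogen therefore matters, as this one swap moves the stabilisation of the target by more than the scatter, something the earlier pair, differing in several places, could not show. Nothing measured here bears on why the number falls.

Still open, from the compounds shown here alone, is whether losing the methyl or gaining the two fluorines carries the step, a question that a plain phenyl on this nitrogen could help to separate. Also open, going by these compounds, is how an amine, a methoxy group or a carboxylic acid on that ring would read.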